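This account rests on a few compounds, and the source may have more. Where it says the series, first, only, none or still open, it means among the compounds named here.

Measured so far in an assay on isolated protein for inhibition of DNA topoisomerase 1 (Homo sapiens), with a stated time of 30 min, tested at 100 uM; on this read-out lower numbers stand for a weaker effect and higher numbers for a stronger effect at the one concentration tested:
- compound 1 `Oc1cccc(-c2cc(-c3cccs3)nc(-c3ccccc3Cl)c2)c1`: 2.7%
- compound 2 `Oc1cccc(-c2cc(-c3ccccc3)nc(-c3ccccc3Cl)c2)c1`: 3.2%

Compound 2 gives the highest of the two numbers, yet its nearest neighbour, compound 1, lies within the scatter of it, so the two are not distinguished by this assay. Going by the values given here, the only measured step, a number 0.5 percentage points higher from compound 1 to compound 2 (within the scatter), exchanges one aromatic ring for another at a single aromatic carbon of the shared core and stays within the scatter.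

Compound 3 `Oc1cccc(-c2cc(-c3ccco3)nc(-c3ccccc3Cl)c2)c1` is not yet measured. It differs from compound 2 as follows: furan-2-yl in place of phenyl on an aromatic carbon. The step from compound 1 to compound 2 bears on this change, since it also replaces the aromatic ring at the same place, and it was small. A move to furan-2-yl is therefore expected to behave alike, with no step beyond the scatter; the expected step is a number 0.3 percentage points higher from compound 2 to compound 3 (within the scatter). Compound 3 is accordingly estimated to give 3.5% in this assay, with an expected range from 0% to 12%.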

Compound 3, a percentage reported as inhibition, at one concentration (the size of the read-out at that concentration, not a potency): 0%
Beside the measured number, compound 3's estimate is 3.5 percentage points above it; low and high end bracket the measured number.
By their numbers in this assay, from the lowest: compounds 3, 1 and 2 (each within the scatter of the next).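

In this assay, the change at this aromatic carbon, next to the ring nitrogen, now covers three aromatic rings: putting furan-2-yl in place of phenyl gives a number 3.2 percentage points lower from compound 2 to compound 3 (within the scatter), and putting furan-2-yl in place of thiophen-2-yl gives a number 2.7 percentage points lower from compound 1 to compound 3 (within the scatter). The position therefore tolerates a change from a six-membered ring of carbon only, with 0 hydrogen-bond acceptors, to a five-membered ring with 1 hetero atom and 1 hydrogen-bond acceptor, without any separation in this read-out, so the three compounds cannot be ranked. No evidence is available that bears on the origin of these numbers.

As far as these compounds go, all three compounds carry an aromatic ring at this place, so it remains open whether an amine, a carboxylic acid or a longer alkyl chain there would move the number beyond the scatter. The 2-chlorophenyl and 3-hydroxyphenyl groups are also the same throughout, which leaves open how the read-out responds to a change at either of them, for instance a methoxy group in place of the hydroxyl.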